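The source may hold more compounds than are shown below. What is called first, only, known or untested is meant among the compounds shown, and "the series" means these compounds.

In a functional assay on DU-145 cells (Homo sapiens) for cytotoxicity, read by sulforhodamine B assay, with a stated time of 48 h (a lower number here means a stronger inhibitor, a higher number a weaker inhibitor), two compounds have been measured:

Compound 1 `CC(=O)OC[C@H]1O[C@@H](n2cc(CN3C(=O)/C(=C\c4ccccc4)c4ccccc43)nn2)[C@H](OC(C)=O)[C@@H](OC(C)=O)[C@@H]1OC(C)=O`: 24100 nM
Compound 2 `CC(=O)OC[C@H]1O[C@@H](n2cc(CN3C(=O)/C(=C/c4ccccc4)c4ccccc43)nn2)[C@H](OC(C)=O)[C@@H](OC(C)=O)[C@@H]1OC(C)=O`: 22800 nM

Among the measured compounds shown here, compound 1 stands level with compound 2, the only other compound measured, and the gap between them is a 1.1-fold lower number from compound 1 to compound 2 (0.02 log units; within the scatter). The two are separated only by the fact that compounds 1 and 2 differ only in the configuration as drawn.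

Compound 3 `CC(=O)OC[C@H]1O[C@@H](n2cc(CN3C(=O)/C(=C\c4ccc(N(C)C)cc4)c4ccccc43)nn2)[C@H](OC(C)=O)[C@@H](OC(C)=O)[C@@H]1OC(C)=O` keeps the core of compound 1 but has dimethylamino in place of hydrogen on an aromatic carbon, para to a large group: dimethylamino in place of hydrogen on an aromatic carbon. The phenyl group thus becomes 4-(dimethylamino)phenyl.

For the measured compounds named here, the one measured step bears on this change only indirectly. It shows that altering the drawn configuration left the number within the scatter, but it does not test any substituent on the aromatic ring. Going by the values given here, no measured compound carries dimethylamino, so the data give no firm size or direction for this change. A step beyond the scatter is therefore not expected, although a slight lean toward a lower number is allowed, and the range is kept wide.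

For compound 3, the expected value is 16000 nM, with an estimated range from 6000 nM to 42000 nM.

This estimate corresponds to an expected 1.5-fold lower number from compound 1 to compound 3 (0.18 log units; within the scatter).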

Compound 3, half-maximal inhibitory concentration: 10100 nM
Beside the measured number, compound 3's estimate is 1.6-fold (0.20 log units) above it, within the range that was stated.
By their numbers in this assay, from the lowest: compound 3; then compounds 2 and 1 (each within the scatter of the next).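

In this assay, placing dimethylamino on the aromatic carbon para to a large group, which turns phenyl into 4-(dimethylamino)phenyl, gives a 2.4-fold lower number from compound 1 to compound 3 (0.38 log units; beyond the scatter). Among the compounds shown here, this is the first change to go beyond the scatter, so this position on the ring can move the number, and here it moves toward stronger inhibition, although only modestly, as compound 3 still gives 10100 nM. The earlier comparison could say nothing about a substituent on this ring, because it involved no change of atoms or bonds: the fact that compounds 1 and 2 differ only in the configuration as drawn.

From the compounds shown here alone, with a single substituent in hand, it remains open whether the step belongs to dimethylamino itself or would appear with other groups at this place, such as methoxy, chlorine, a primary amine or a carboxylic acid. Going by these compounds, it is also open whether the drawn configuration of the double bond would still leave the number within the scatter once dimethylamino is present, and whether the same change would carry over to other cell lines.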